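The source may report more compounds than this note shows. Statements on the series, on what has been measured and on what is new or still open speak of the compounds shown alone.

Measured so far in an assay on isolated protein for inhibition of Apoptosis regulator Bcl-2 (Homo sapiens), read by fluorescence polarization; a higher number here means a weaker inhibitor, a lower number a stronger inhibitor:
compound 1 `O=C(O)c1ccc([N+](=O)[O-])c(COc2ccc(/C=C3\SC(=S)N(c4ccccc4)C3=O)cc2)c1`, giving 9000 nM;
compound 2 `COc1ccccc1N1C(=O)/C(=C/c2ccc(OCc3ccc(C(=O)O)cc3)cc2)SC1=S`, giving 2000 nM;
compound 3 `O=C(Nc1cccc(C(=O)O)c1O)c1ccc(/C=C2\SC(=S)N(c3ccc([N+](=O)[O-])cc3)C2=O)cc1`.

For compound 3 this assay reports only a limit, > 10000 nM, as noted in the limit of > 10000 nM in this assay, at which 1 of the 3 values shown sits. Among the two plain numbers, compound 2 stands lowest, and the number for compound 1 lies higher by more than the usual scatter. Compound 4 `O=C(O)c1ccc(COc2ccc(/C=C3\SC(=S)N(c4ccc(Br)cc4)C3=O)cc2)cc1` shares the core of compound 2 and differs from it in one place: 4-bromophenyl in place of 2-methoxyphenyl on an amide-type nitrogen in a ring. Among the measured compounds shown here, no measured pair shows what such a swap does here, so the size of the step in this assay is open. The expected change from compound 2 to compound 4 is small, a 1.5-fold higher number from compound 2 to compound 4 (0.18 log units; within the scatter), and may stay within the scatter. Compound 4 is estimated at 3000 nM, ranging from 1000 nM to 10000 nM.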

Compound 4, inhibition constant: 610 nM
The estimate for compound 4 lay 4.9-fold (0.69 log units) above the measured number; the measured number lies below the stated range.
By their numbers in this assay, from the lowest: compound 4; then compound 2; then compound 1. At a limit, above all of these: compound 3.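

On the amide-type nitrogen of the shared ring, the choice of substituted phenyl group matters: in this assay, 4-bromophenyl in place of 2-methoxyphenyl gives a 3.3-fold lower number from compound 2 to compound 4 (0.52 log units; beyond the scatter). Among the compounds shown here, this is the first measured step at this position, and it runs toward a stronger inhibitor. Nothing measured here accounts for the step. As far as these compounds go, it remains open whether the gain comes from adding the bromine or from losing the methoxy group, and how an amine or a longer chain on that phenyl ring would fare.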